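Terminal aryl exchange on the shared core

The source may report more compounds than this note shows. Statements on the series, on what has been measured and on what is new or still open speak of the compounds shown alone.

Measured compounds in a functional assay on Sf9 cells for antagonist activity at histamine H2 receptor (Homo sapiens), with stated times of 2 min and 20 min; a higher number here means a more potent compound, by a factor of ten per unit of this negative logarithm, a lower number a less potent compound:
compound 1 `N/C(=N\C(=O)CC(c1ccccc1)c1ccccc1)NCCCc1ccccc1` gives 5.89
compound 2 `N/C(=N\C(=O)CC(c1ccccc1)c1ccccc1)NCCCc1cccnc1` gives 6.14
compound 3 `N/C(=N\C(=O)CC(c1ccccc1)c1ccccc1)NCCCc1ccncc1` gives 6.14

Compound 3 sits level with compound 2 at the digits recorded, the two together the highest of the three numbers, and its nearest neighbour is compound 2 with no change at the digits printed from compound 2 to compound 3 (within the scatter). Furthest is compound 1, with a number 0.25 log units higher from compound 1 to compound 3 (within the scatter); the parallel exchange a number 0.25 log units higher from compound 1 to compound 2 (within the scatter) is of the same size. All three steps lie within the scatter, so the three aryl groups at this position have not separated in this assay.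

Compound 4 `CN(C)Cc1ccc(CCCN/C(N)=N/C(=O)CC(c2ccccc2)c2ccccc2)o1` carries the change (5-((dimethylamino)methyl)furan-2-yl in place of pyridin-4-yl on a saturated chain carbon, three bonds along the chain from an amine nitrogen). Among the compounds with values here, the steps that bear on it are the three aryl exchanges above, each within the scatter. The new group is larger than any of those exchanges and not covered by them, so the expectation is loose: a step of a number 0.36 log units higher from compound 3 to compound 4 (beyond the scatter) is expected, upward but uncertain. Compound 4 is estimated at 6.5, within 5.9 to 7.2.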

Compound 4, negative logarithm of the antagonist equilibrium constant: 7.03
The estimate for compound 4 lay 0.53 log units below the measured number; low and high end bracket the measured number.
By their numbers in this assay, from the lowest: compounds 1, 2 and 3 (each within the scatter of the next); then compound 4.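

In this assay, within the data shown here, the 5-((dimethylamino)methyl)furan-2-yl group is the first terminal group at this place to separate from the others: a number 0.89 log units higher from compound 3 to compound 4 (beyond the scatter), a number 0.89 log units higher from compound 2 to compound 4 (beyond the scatter), and a number 1.14 log units higher from compound 1 to compound 4 (beyond the scatter). The position is therefore not indifferent to the terminal group, even though phenyl, pyridin-3-yl and pyridin-4-yl did not separate from one another here. No measurement at hand accounts for the gain.

The change replaces the ring and adds the dimethylaminomethyl group in a single step, so the compounds shown leave open which of the two carries the gain. A plain furan-2-yl and a phenyl bearing a dimethylaminomethyl group, each on the same chain, would divide the step between the two parts.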